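Hydroxy to methyl on two coumarin-triazole cores

This account rests on a few compounds, and the source may have more. Where it says the series, first, only, none or still open, it means among the compounds named here.

The measured compounds and their values are these:
Compound 1, `O=c1cc(Cn2cc(-n3ccc4cc(I)ccc43)nn2)c2ccc(O)cc2o1`, in a functional assay on CFPAC-1 cells (Homo sapiens) for inhibition, read by MTT assay, with a stated time of 72 h (on this read-out lower numbers stand for stronger inhibition and higher numbers for weaker inhibition), gives 29900 nM.
Compound 2, `Cc1ccc2c(Cn3cc(-n4ccc5cc(I)ccc54)nn3)cc(=O)oc2c1`, in this assay gives 41700 nM.
Compound 3, `Cn1c(-c2cn(Cc3cc(=O)oc4cc(O)ccc34)nn2)nc2ccccc21`, in this assay gives 76500 nM.

Compound 1 and compound 2 differ in one place: methyl in place of hydroxy on an aromatic carbon. This change gave a 1.4-fold higher number from compound 1 to compound 2 (0.14 log units; within the scatter), so the two numbers cannot be told apart by this assay. Compound 3 carries a different core; how it differs from compound 1 is not broken down here. What the two values show is that compound 3 returns the higher number of the pair, with a gap beyond the scatter, while its gap to compound 2 lies within the scatter.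

Compound 4, `Cc1ccc2c(Cn3cc(-c4nc5ccccc5n4C)nn3)cc(=O)oc2c1`, has not yet been measured. It differs from compound 3 by methyl in place of hydroxy on an aromatic carbon, the same change that turned compound 1 into compound 2, at the same kind of place on the ring. Because compound 1 to compound 2 gave a 1.4-fold higher number from compound 1 to compound 2 (0.14 log units; within the scatter), the step from compound 3 to compound 4 in this assay is expected to be small as well, about a 1.3-fold higher number from compound 3 to compound 4 (0.12 log units; within the scatter). On that basis compound 4 is estimated at 100000 nM in this assay, with a range from 45000 nM to 220000 nM expected. This rests on a single earlier instance of the change, so the expectation is loose.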

Compound 4, half-maximal inhibitory concentration: 59400 nM
Estimate against measurement, compound 4: 1.7-fold (0.23 log units) above, and the stated range covers the measured number.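

In this assay, methyl in place of hydroxy on an aromatic carbon gave a 1.3-fold lower number from compound 3 to compound 4 (0.11 log units; within the scatter), so on this core too the two numbers cannot be told apart. Set beside the earlier pair, the change carries from one core to the other without a detectable difference: the same change on two cores in this assay, a 1.4-fold higher number (0.14 log units; within the scatter) from compound 1 to compound 2 and a 1.3-fold lower number (0.11 log units; within the scatter) from compound 3 to compound 4, 1.8-fold (0.25 log units) apart, within the scatter of two such steps. This shows that, in these two pairs, exchanging hydroxy for methyl left the number within the scatter on both cores, and that the opposite directions of the two steps should not be read as a real difference; it does not show that hydroxy and methyl are interchangeable on other cores or in other assays, nor does it exclude a small effect that this assay cannot resolve, and two pairs are too few to establish a rule for the series.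

The compounds shown leave open whether an amine, a methoxy group or a carboxylic acid on that aromatic carbon, or a chain longer than methyl, would move the number beyond the scatter. They also leave open whether the change would behave in the same way on any core other than these two.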